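Series notes: amine substituent on the shared core

The source may hold more compounds than are shown below. What is called first, only, known or untested is meant among the compounds shown, and "the series" means these compounds.

In an assay on CHO cells for displacement of a labelled ligand from adenosine receptor A1 (Homo sapiens), read by scintillation counting, with a stated time of 1 h, tested at 1 uM (a lower number here means less inhibition, a higher number more inhibition at the concentration tested (going by the name of the read-out)), compound 1 `CCCC(=O)Nc1ncc(-c2cccc(Cl)c2)c(-c2ccccc2)n1` gives > 80%, which is a limit of the assay rather than a number. Compound 2 `Clc1cccc(-c2cnc(Nc3ccccc3)nc2-c2ccccc2)c1` gives 34% in this assay. Among the compounds with values here, the step of a number at least 46 percentage points lower from compound 1 to compound 2 (beyond the scatter) is the only measured step in the set. Within the data shown here, compound 2 thus holds the only plain number on record, the other value being a limit of the assay, as noted under (the limit of > 80% in this assay, at which 1 of the 2 values shown sits).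

Compound 3 `CC(C)CCNc1ncc(-c2cccc(Cl)c2)c(-c2ccccc2)n1` has not yet been measured in this assay. It differs from compound 2 as isopentyl in place of phenyl on a nitrogen on an aromatic ring. Among the measured compounds shown here, only the step between compound 1 and compound 2 bears on the substituent at this nitrogen, and that step was large; it exchanged propylcarbonyl for phenyl, not phenyl for isopentyl, so it shows how much this position can move the read-out without fixing the direction of the present change. A moderate rise is expected for compound 3 relative to compound 2, a number 16 percentage points higher from compound 2 to compound 3 (beyond the scatter), with the outcome uncertain. The estimate for compound 3 in this assay is 50%, with a range from 20% to 85%.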

Compound 3, a percentage reported as inhibition, at one concentration (the size of the read-out at that concentration, not a potency): 39%
Compound 3: the middle estimate sits 11 percentage points above what was measured, within the range that was stated.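

In this assay, anilino to isopentylamino gives a number 5 percentage points higher from compound 2 to compound 3 (within the scatter), so at this nitrogen a phenyl ring and a branched open chain are not told apart by this read-out. With a number at least 41 percentage points lower from compound 1 to compound 3 (beyond the scatter) standing alongside a number at least 46 percentage points lower from compound 1 to compound 2 (beyond the scatter), the large gap to compound 1 no longer rests on the phenyl group alone: it holds for both an aromatic and an open-chain substituent, and among the three compounds, only compound 1 carries a carbonyl on this nitrogen. The entry for compound 1 is a limit of the assay, not a number: the limit of > 80% in this assay, at which 1 of the 3 values shown sits.

The compounds shown leave open whether the higher inhibition goes with the carbonyl itself or with the propyl chain attached to it, and how much of the read-out remains with neither substituent. A benzoyl group on this nitrogen would join the phenyl of compound 2 to the carbonyl of compound 1, while an unsubstituted amino group would give the reading for the shared core without either, and neither reading would by itself give a potency, as the read-out comes from one concentration.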